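Notes on the step from compound 3 to compound 4

The source may report more compounds than this note shows. Statements on the series, on what has been measured and on what is new or still open speak of the compounds shown alone.

Values measured in a functional assay on KB cells (Homo sapiens) for cytotoxicity (a higher number here means a weaker inhibitor, a lower number a stronger inhibitor), are as follows
- compound 1 `COc1ccc(S(=O)(=O)N2CCc3cccc(NC(=O)C(C)(C)C)c32)cc1` gives 359 nM
- compound 2 `COC(=O)c1ccc(C(=O)Nc2cccc3c2N(S(=O)(=O)c2ccc(OC)cc2)CC3)cc1` gives 376 nM
- compound 3 `COc1ccc(S(=O)(=O)N2CCc3cccc(NC(=O)c4ccccc4)c32)cc1` gives 297 nM

Compound 3 at 297 nM stands level with the other two compounds, as all three values lie within the scatter of each other. The next compound, compound 4 `COc1ccc(S(=O)(=O)N2CCc3cccc(NC(=O)N(C)c4ccccc4)c32)cc1`, carries methyl(phenyl)amino in place of phenyl on a carbonyl carbon in the structural comparison. Among the compounds with values here, three measured steps bear on this. Changes to the group on the carbonyl carbon gave a 1.2-fold lower number from compound 1 to compound 3 (0.08 log units; within the scatter) and a 1.0-fold higher number from compound 1 to compound 2 (0.02 log units; within the scatter) while the change on an aromatic carbon gave a 1.3-fold lower number from compound 2 to compound 3 (0.10 log units; within the scatter) and all of these lie within the scatter. Within the data shown here, no measured compound carries methyl(phenyl)amino on that carbonyl carbon, so the data offer no direct precedent and the range is kept wide. In this assay no step beyond the scatter is expected, and the estimate amounts to a 1.1-fold higher number from compound 3 to compound 4 (0.05 log units; within the scatter) without a firm direction. Compound 4 is estimated at 330 nM with an expected range from 120 nM to 900 nM for this measurement.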

Compound 4, half-maximal inhibitory concentration: > 10000 nM
Compound 4 gave a limit, no number; the forecaster's own chance of this, stated with the estimate: 3%; middle value at least 30-fold (1.48 log units) away from the limit.
By their numbers in this assay, from the lowest: compounds 3, 1 and 2 (each within the scatter of the next). At a limit, above all of these: compound 4.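

In this assay, tert-butyl, phenyl and 4-(methoxycarbonyl)phenyl on the carbonyl carbon had all stayed within the scatter of each other, so this position had shown no sensitivity until methyl(phenyl)amino entered. That replacement gives an at least 33-fold higher number from compound 3 to compound 4 (1.52 log units; beyond the scatter), and the comparisons with the other two groups read the same way, with an at least 26-fold higher number from compound 2 to compound 4 (1.42 log units; beyond the scatter) and an at least 27-fold higher number from compound 1 to compound 4 (1.44 log units; beyond the scatter), so the position does not tolerate every group carrying a phenyl ring. The value of compound 4 is a limit of the assay and not a number: the limit of > 10000 nM in this assay, at which 1 of the 4 values shown sits.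

As far as these compounds go, it remains open whether the step follows from the nitrogen on the carbonyl carbon or from its methyl group. From the compounds shown here alone, a phenylamino group or a dimethylamino group at this place would separate the two, and how far the step extends stays unknown.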